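Replacing tert-butoxy on a carbonyl carbon with a pyrazole

The source may hold more compounds than are shown below. What is called first, only, known or untested is meant among the compounds shown, and "the series" means these compounds.

Of the compounds shown here, two have so far been measured in an ADME assay on the whole organism (Mus musculus, strain BALB/c) for pharmacokinetics, read by LC-MS, at a dose of 3 mg/kg by the intravenous route (on this read-out higher numbers stand for wider distribution into tissues and lower numbers for narrower distribution), and they sit well apart. Compound 1 (`CCn1nc(C)cc1C(=O)NCCCCn1c(NC(=O)c2cc(C)nn2CC)nc2cc(C(N)=O)ccc21`) gives 1.8 L/kg while compound 2 (`CCn1nc(C)cc1C(=O)Nc1nc2cc(C(N)=O)cc(OC)c2n1C/C=C/Cn1c(NC(=O)c2cc(C)nn2CC)nc2cc(C(N)=O)cc(OCCCNC(=O)OC(C)(C)C)c21`) gives 17.7 L/kg as the higher of the two numbers, and the gap between them lies beyond the usual scatter. These two compounds do not differ in one place only, so their values offer no direct guide to a single change.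

Compound 3 (`CCn1nc(C)cc1C(=O)NCCCOc1cc(C(N)=O)cc2nc(NC(=O)c3cc(C)nn3CC)n(C/C=C/Cn3c(NC(=O)c4cc(C)nn4CC)nc4cc(C(N)=O)cc(OC)c43)c12`) has not yet been measured. Its difference from compound 2 is 1-ethyl-3-methyl-1H-pyrazol-5-yl in place of tert-butoxy on a carbonyl carbon and amounts to 1-ethyl-3-methyl-1H-pyrazol-5-yl in place of tert-butoxy on a carbonyl carbon. Going by the values given here, no measured pair shows this change on its own, and the rest of the structure stays the same. Compound 2 at 17.7 L/kg is therefore the only anchor for the expectation, which is for no step beyond the scatter in this assay and only a slight lean towards a lower number. The expected change is a 1.3-fold lower number from compound 2 to compound 3 (0.10 log units; within the scatter) on this estimate. For compound 3 the estimated value is 14 L/kg with an expected range of 6 L/kg to 30 L/kg as the likely span.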

Compound 3, volume of distribution at steady state: 1.81 L/kg
Compound 3: the middle estimate sits 7.7-fold (0.89 log units) above what was measured, outside the stated range (below it).
By their numbers in this assay, from the lowest: compounds 1 and 3 (each within the scatter of the next); then compound 2.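

In this assay, going by these compounds alone, putting 1-ethyl-3-methyl-1H-pyrazol-5-yl in place of tert-butoxy on a carbonyl carbon whose other neighbour is an amide-type nitrogen gives a 9.8-fold lower number from compound 2 to compound 3 (0.99 log units; beyond the scatter), the first step in this set that can be read at a single place. It shows that this one place, with the rest of the structure unchanged, can carry a step beyond the scatter, something the first two compounds could not show since they differ in more than one place. Nothing given here speaks to what lies behind the step.

On these data alone, the step rests on a single pair, so it remains open whether it follows from the departure of tert-butoxy or from the arrival of the pyrazole, and whether it would recur on a different structure. Also open, as far as these compounds go, is how other groups on the same carbonyl carbon, such as methyl, phenyl or a dimethylamino group, would read in this assay, and so whether the read-out there follows any trend or belongs to these two groups alone.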